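Swapping one sulfonyl aryl group: what to expect for compound 4

A few compounds are considered here, and "the series" means these few. Any claim that something is new, unique, unknown or untested is made for them only; others in the source may bear on it.

Compound 1 `N#C/C(=C\c1ccccc1OS(=O)(=O)c1ccccc1[N+](=O)[O-])C(=O)Nc1nnc(Cc2cccc3ccccc23)s1` gives 23%.
Compound 2 `N#C/C(=C\c1ccccc1OS(=O)(=O)c1ccc(Cl)cc1)C(=O)Nc1nnc(Cc2cccc3ccccc23)s1` gives 15%.
Compound 3 `Cc1ccc(Cc2nnc(NC(=O)/C(C#N)=C/c3ccccc3OS(=O)(=O)c3ccccc3[N+](=O)[O-])s2)cc1` gives 33%.

All three were tested in a functional assay on HL-60 cells (Homo sapiens) for inhibition, read by CCK-8 assay, with a stated time of 48 h, tested at 20 uM; a lower number here means less inhibition of growth, a higher number more inhibition of growth at the concentration tested. Compound 3 has the highest of the three numbers, yet its nearest neighbour compound 1 lies within the scatter, so no order between these two is claimed; only the gap from compound 3 down to compound 2 lies beyond the scatter.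

Two structural changes appear. The first is 4-chlorophenyl in place of 2-nitrophenyl on a sulfonyl sulfur. In this assay that gave a number 8 percentage points lower from compound 1 to compound 2 (within the scatter). The second is 4-methylphenyl in place of naphthalen-1-yl on a saturated chain carbon bound to an aromatic carbon, which is how the core of compound 1 differs from the core of compound 3; it gave a number 10 percentage points higher from compound 1 to compound 3 (within the scatter).

Compound 4 `Cc1ccc(Cc2nnc(NC(=O)/C(C#N)=C/c3ccccc3OS(=O)(=O)c3ccc(Cl)cc3)s2)cc1` has not been measured. It differs from compound 3 by 4-chlorophenyl in place of 2-nitrophenyl on a sulfonyl sulfur, the same change as that between compound 1 and compound 2, made at the same place on a core that differs only as described above. The expected step is therefore a number 8 percentage points lower from compound 3 to compound 4 (within the scatter), set beside the measured one because a number 8 percentage points lower from compound 1 to compound 2 (within the scatter) was small. Compound 4 is thus estimated at 25%, likely between 10% and 40%.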

Compound 4, percent growth inhibition at one concentration: 38%
Estimate against measurement, compound 4: 13 percentage points below; the range from low to high includes it.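

In this assay, putting 4-chlorophenyl in place of 2-nitrophenyl gave a number 5 percentage points higher from compound 3 to compound 4 (within the scatter), and the two readings of this change cannot be told apart: the same change on two cores in this assay, a number 8 percentage points lower (within the scatter) from compound 1 to compound 2 and a number 5 percentage points higher (within the scatter) from compound 3 to compound 4, 13 percentage points apart, within the scatter of two such steps. Putting 4-methylphenyl in place of naphthalen-1-yl gave a number 23 percentage points higher from compound 2 to compound 4 (beyond the scatter), and this change also reads alike on both cores: the same change on two cores in this assay, a number 10 percentage points higher (within the scatter) from compound 1 to compound 3 and a number 23 percentage points higher (beyond the scatter) from compound 2 to compound 4, 13 percentage points apart, within the scatter of two such steps. So neither change is shown to behave differently from one core to the other, but this does not prove that the steps are equal, as each change has only two readings and a real difference of moderate size could stay hidden in the scatter.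

The compounds shown leave open how other groups on the sulfonyl sulfur would read, such as a phenyl ring carrying an amine or a carboxylic acid. They also leave open what a longer chain would do in place of the 4-methylphenyl group.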